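Shortening the Unsaturated Chain of an Ester

The source may hold more compounds than are shown below. What is called first, only, known or untested is meant among the compounds shown, and "the series" means these compounds.

Measured so far:
Compound 1 `CCCCCCCC/C=C\CCCCCCCC(=O)OCC1CCCCO1` gives 35% in an assay on membranes from cerebellum for inhibition of Monoglyceride lipase (Rattus norvegicus), tested at 100 uM; a lower number here means less inhibition, a higher number more inhibition at the concentration tested (going by the name of the read-out).
Compound 2 `O=C(OCC1CO1)c1ccccc1` gives 0.2% in this assay.
Compound 3 `O=C(OCC1CCCCO1)c1cccc(-c2ccccc2)c1` gives 49% in this assay.

Among these three, compound 1 stands second highest. Compound 3 lies above it by a margin beyond the scatter, and compound 2 lies well below it, also beyond the scatter. Compound 1 thus gives a middling number with a long unsaturated chain, clearly above compound 2 and below the biphenyl ester compound 3.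

Compound 4 `CCCCCC/C=C\CCCCCCCC(=O)OCC1CCCCO1` is the next compound, not yet measured in this assay. It differs from compound 1 in one place: hydrogen in place of ethyl on a saturated chain carbon, six bonds along the chain from a double-bonded chain carbon. The chain keeps its double bond and its ester; only its far end is trimmed.

Among the measured compounds shown here, no measured pair shows the effect of such a trim, so the expectation rests on compound 1 alone. Since compound 1 gives 35%, the step from it to compound 4 is expected to be small, if anything a slight drop, at a number 5 percentage points lower from compound 1 to compound 4 (within the scatter), and not clearly beyond the scatter. Compound 4 is therefore estimated at 30%, between 15% and 45%.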

Compound 4, a percentage reported as inhibition, at one concentration (the size of the read-out at that concentration, not a potency): 36%
The estimate for compound 4 lay 6 percentage points below the measured number, and the stated range covers the measured number.
By their numbers in this assay, from the lowest: compound 2; then compounds 1 and 4 (each within the scatter of the next); then compound 3.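

Replacing ethyl with hydrogen on a saturated chain carbon, six bonds along the chain from a double-bonded chain carbon, gives in this assay a number 1 percentage points higher from compound 1 to compound 4 (within the scatter). Among the compounds shown here, this is the first pair that differs in one place, and it shows that this end of the chain can lose its ethyl without a change that stands out from the scatter. Nothing at hand speaks to why the number holds at this position.

Still open, from the compounds shown here alone, is whether a longer chain, an amine or a carboxylic acid at this same place would also leave the number within the scatter. Going by these compounds, it is equally open whether trimming further along the chain, closer to the double-bonded carbons, would hold the number.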